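Replacing pyridin-4-yl with 4-chlorophenyl on an oxygen

The source may report more compounds than this note shows. Statements on the series, on what has been measured and on what is new or still open speak of the compounds shown alone.

Of the compounds shown here, two have been measured so far in a physicochemical assay for metabolic stability, read by HPLC; on this read-out lower numbers stand for a shorter-lived compound and higher numbers for a longer-lived compound. Compound 1 `O=c1ccn([C@H]2CC[C@@H](COP(=O)(O)Oc3ccccc3)O2)c(=O)[nH]1` gives 25.1 h, and compound 2 `Cc1cn([C@H]2C[C@H](N=[N+]=[N-])[C@@H](COP(=O)(O)Oc3ccncc3)O2)c(=O)[nH]c1=O` gives 8.07 h. Compound 2 therefore holds the lower of the two numbers, and the gap lies beyond the usual scatter. The next compound is compound 3 `Cc1cn([C@H]2C[C@H](N=[N+]=[N-])[C@@H](COP(=O)(O)Oc3ccc(Cl)cc3)O2)c(=O)[nH]c1=O`, which carries 4-chlorophenyl in place of pyridin-4-yl on an oxygen. Among the measured compounds shown here, no measured pair isolates this change, since compound 1 and compound 2 differ in more than one place. For the measured compounds named here, the only guide is that compound 1 at 25.1 h shows a longer half-life than compound 2, so a moderate rise in this assay is expected, near the edge of the scatter. The estimated step is a 1.9-fold higher number from compound 2 to compound 3 (0.27 log units; within the scatter). For compound 3 the estimated half-life is 15 h, with an expected range of 7 h to 32 h.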

Compound 3, half-life: 5.5 h
The estimate for compound 3 lay 2.7-fold (0.44 log units) above the measured number, and the stated range ends above it.
By their numbers in this assay, from the lowest: compounds 3 and 2 (each within the scatter of the next); then compound 1.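

In this assay, the first change isolated at the oxygen whose other neighbour is phosphorus gives a 1.5-fold lower number from compound 2 to compound 3 (0.17 log units; within the scatter). Pyridin-4-yl and 4-chlorophenyl therefore cannot be told apart at this position on this read-out, even though the change removes the ring nitrogen and brings in a chlorine. No supporting measurement is available to explain this result.

From the compounds shown here alone, whether an aryl group carrying an amine or a carboxylic acid on this oxygen would leave the half-life just as unchanged remains open. Compound 1 differs from compound 2 and from compound 3 in more than one place, so the contribution of each of its differences to the half-life also remains unresolved.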